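Benzyl on an amine nitrogen of compound 1

The source may hold more compounds than are shown below. What is called first, only, known or untested is meant among the compounds shown, and "the series" means these compounds.

Measured in a functional assay on PC-3 cells (Homo sapiens) for cytotoxicity, read by MTT assay, with a stated time of 96 h; on this read-out higher numbers stand for weaker inhibition and lower numbers for stronger inhibition:
- compound 1 `CC[C@H](N)C(=O)N[C@@H]1C(=O)N2[C@@H](CC[C@@H]1CCN)CC[C@H]2C(=O)NC(c1ccccc1)c1ccccc1`: 85200 nM
- compound 2 `CC[C@H](NC)C(=O)N[C@@H]1C(=O)N2[C@@H](CC[C@@H]1CCN)CC[C@H]2C(=O)NC(c1ccccc1)c1ccccc1`: > 100000 nM (a limit of the assay, not a number)
- compound 3 `CC[C@H](NC)C(=O)N[C@@H]1C(=O)N2[C@@H](CC[C@@H]1CCNC(=O)NCc1ccccc1)CC[C@H]2C(=O)NC(c1ccccc1)c1ccccc1`: 83500 nM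

Among the measured compounds shown here, compound 1 and compound 3 are the only two with true numbers, and they lie within the scatter of each other. The third value is a limit.

The next compound is compound 4 `CC[C@H](N)C(=O)N[C@@H]1C(=O)N2[C@@H](CC[C@@H]1CCNCc1ccccc1)CC[C@H]2C(=O)NC(c1ccccc1)c1ccccc1`. The change is benzyl in place of hydrogen on an amine nitrogen, turning 2-aminoethyl into 2-(benzylamino)ethyl.

For the measured compounds named here, two measured steps bear on this. Methyl in place of hydrogen on an amine nitrogen gave an at least 1.1-fold higher number from compound 1 to compound 2 (0.06 log units; that floor lies within the scatter). Adding benzylcarbamoyl, the closer match, gave an at least 1.1-fold lower number from compound 2 to compound 3 (0.07 log units; that floor lies within the scatter). Both sizes are only floors, set by the limit of > 100000 nM in this assay, at which 1 of the 3 values shown sits, so they are weak guides. Neither shows a change beyond the scatter, so none is expected here in this assay.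

For compound 4 the expected value is 60000 nM, with an estimated range of 20000 nM to 100000 nM. This estimate amounts to a 1.4-fold lower number from compound 1 to compound 4 (0.15 log units; within the scatter).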

Compound 4, half-maximal inhibitory concentration: 39200 nM
For compound 4 the middle estimate is 1.5-fold (0.18 log units) above the measured one; the measured number falls inside the stated range.
By their numbers in this assay, from the lowest: compound 4; then compounds 3 and 1 (each within the scatter of the next). At a limit, above all of these: compound 2.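

In this assay, benzyl on the nitrogen of the 2-aminoethyl chain gives a 2.2-fold lower number from compound 1 to compound 4 (0.34 log units; beyond the scatter), the first step among these compounds that lies beyond the scatter, though it is modest in size. Among the compounds shown here, this shows that a change at this nitrogen can go with stronger inhibition, which the earlier steps could not show. Compound 2 stands at a limit, so the benzylcarbamoyl step from it on this same nitrogen is only a floor: the limit of > 100000 nM in this assay, at which 1 of the 4 values shown sits.

Going by these compounds, whether the aromatic ring itself matters stays open, since a cyclohexylmethyl group on this nitrogen would separate the ring from the bulk of the chain. Also open, on these data alone, is how the distance to the ring counts, which a longer chain such as 2-phenylethyl would address.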